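This account rests on a few compounds, and the source may have more. Where it says the series, first, only, none or still open, it means among the compounds named here.

Working notes on the series of hydrazone-linked analogues sharing the core shown in compound 1 `CC(C)(C)c1cc2c(N/N=C/c3ccc(O)cc3)ncnc2s1`. Three compounds have been run in a functional assay on HCT-116 cells (Homo sapiens) for cytotoxicity, read by MTT assay, with a stated time of 3 days; on this read-out higher numbers stand for weaker inhibition and lower numbers for stronger inhibition. Compound 1, which carries a hydroxy on the pendant aromatic ring, gives 0.844 ug/mL, the highest number of the three. Compound 2 `CN1Cc2ccc(/C=N/Nc3ncnc4sc(C(C)(C)C)cc34)cc2C1`, in which that ring is fused to a second ring bearing a methylated nitrogen, gives 0.088 ug/mL; compound 3 `CN(C)Cc1cccc(/C=N/Nc2ncnc3sc(C(C)(C)C)cc23)c1`, carrying a dimethylaminomethyl group, gives 0.405 ug/mL. Compound 1 is set apart from both: the gap to compound 3 lies beyond the scatter, and the gap to compound 2 is larger still. Among the measured compounds shown here, no pair among the three differs in one place only, so no single-point step is available.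

The next compound, compound 4 `CNCc1ccc(/C=N/Nc2ncnc3sc(C(C)(C)C)cc23)cc1`, is reached from compound 1 by the change ((methylamino)methyl in place of hydroxy on an aromatic carbon). In this assay a step in the direction of a lower number is expected from compound 1 to compound 4, of roughly the size a 3.8-fold lower number from compound 1 to compound 4 (0.58 log units; beyond the scatter), because compound 3 gives 0.405 ug/mL and compound 2 gives 0.088 ug/mL, both with an amine-bearing carbon chain on that ring and both below compound 1. Compound 4 is therefore estimated at 0.22 ug/mL, within a range of 0.08 ug/mL to 0.55 ug/mL.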

Compound 4, half-maximal inhibitory concentration: 0.056 ug/mL
Compound 4: the middle estimate sits 3.9-fold (0.59 log units) above what was measured; the whole stated range lies above it.
By their numbers in this assay, from the lowest: compounds 4 and 2 (each within the scatter of the next); then compound 3; then compound 1.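

In this assay, among the compounds shown here, replacing hydroxy with (methylamino)methyl on the aromatic carbon para to a large group gives a 15-fold lower number from compound 1 to compound 4 (1.18 log units; beyond the scatter), the first step that can be read at a single place, and a large one, so the read-out responds strongly to what stands at this position while the rest of the molecule stays the same. The computed counts for the two groups match in hydrogen-bond donors and acceptors and in net charge, so this step goes with a change from a single oxygen to a three-atom group of carbon and nitrogen, and not with any difference in those counts. Nothing measured here accounts for the size of the step.

As far as these compounds go, it remains open which part of the entering group carries the step, since a plain methyl, an aminomethyl with a primary amine or a longer chain such as 2-aminoethyl at the same position would separate the contribution of the carbon from that of the nitrogen. A carboxylic acid or a methoxy there would further show how far the result depends on the amine itself.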